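The compounds below may be only part of what the source reports. "The series", "measured", "known", "first", "only" and "open" are said of these compounds alone.

Working notes on the series. Of the compounds shown here, three have been read so far in a functional assay on MCF7 cells (Homo sapiens) for antiproliferative activity, read by CCK-8 assay, with a stated time of 24 h; a higher number here means a weaker inhibitor, a lower number a stronger inhibitor. Compound 1 `CN(C)Cc1ccc2nc(NC(=O)N/N=C/c3ccccn3)sc2c1` gives > 40000 nM, which is a limit of the assay and not a number. Compound 2 `CCN(CC)Cc1ccc2nc(NC(=O)N/N=C(\C)c3ccccn3)sc2c1` gives > 40000 nM, again a limit. Compound 3 `CCN(CC)Cc1ccc2nc(NC(=O)NN=C(c3ccccn3)c3ccccn3)sc2c1` gives > 40000 nM, also a limit. Compound 1 therefore stands where every reading so far stands, and the summary is short: the limit of > 40000 nM in this assay, at which 3 of the 3 values shown sit. Among the compounds with values here, no step between measured compounds is available, so the series offers no measured size of change to build on.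

Compound 4 `CC1CCN(Cc2ccc3nc(NC(=O)N/N=C/c4ccccn4)sc3c2)CC1` differs from compound 1 in one place, with 4-methylpiperidin-1-yl in place of dimethylamino on a saturated chain carbon bound to an aromatic carbon. The expectation rests only on compound 1 and its reading of > 40000 nM, and another limit in this assay would fit it well. The estimated step is an at least 1.1-fold lower number from compound 1 to compound 4 (0.05 log units; that floor lies within the scatter), which is expected to stay within the scatter or lean only slightly towards a stronger inhibitor. For compound 4 the expected value is 35000 nM, with an estimated range from 10000 nM to 80000 nM.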

Compound 4, half-maximal inhibitory concentration: > 40000 nM
Compound 4 ended at the assay's limit; the forecaster's own chance of this, stated with the estimate: 60%; middle value at least 1.1-fold (0.05 log units) away from the limit.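

Compound 1 and compound 4 both stand at a limit of this assay, so the change from dimethylamino to 4-methylpiperidin-1-yl gives no readable step. The compounds shown leave open whether any change to this series yields a measurable value in this assay, and the readings so far offer only one summary: the limit of > 40000 nM in this assay, at which 4 of the 4 values shown sit.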